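Aryl chloro position on the ring amine: compound 3 to compound 4

The compounds below may be only part of what the source reports. "The series", "measured", "known", "first", "only" and "open" are said of these compounds alone.

Three members of this series have been measured in an assay on liver for binding affinity to Alpha-1B adrenergic receptor (Homo sapiens), using microsomes; a higher number here means a weaker inhibitor, a lower number a stronger inhibitor. Compound 1 `COC(=O)C1=C(C)NC(=O)N(C(=O)NCCCN2CCN(c3ccc(Cl)cc3)CC2)C1c1ccc(F)c(F)c1` gives 17 nM. Compound 2 `CCOc1ccccc1N1CCN(CCCNC(=O)N2C(=O)NC(C)=C(C(=O)OC)C2c2ccc(F)c(F)c2)CC1` gives 8.8 nM in this assay. Compound 3 `COC(=O)C1=C(C)NC(=O)N(C(=O)NCCCN2CCN(c3ccccc3Cl)CC2)C1c1ccc(F)c(F)c1` gives 15 nM in this assay, the second highest of the three numbers; its nearest neighbour is compound 1, its furthest compound 2, and both gaps lie within the scatter. The steps recorded so far are small: a 1.9-fold lower number from compound 1 to compound 2 (0.29 log units; within the scatter), a 1.1-fold lower number from compound 1 to compound 3 (0.05 log units; within the scatter) and a 1.7-fold higher number from compound 2 to compound 3 (0.23 log units; within the scatter). Each replaces one group on the amine nitrogen in the ring with another, and none moves the number beyond the scatter.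

Compound 4 `COC(=O)C1=C(C)NC(=O)N(C(=O)NCCCN2CCN(c3cccc(Cl)c3)CC2)C1c1ccc(F)c(F)c1` has not been measured in this assay. Its change from compound 3 is 3-chlorophenyl in place of 2-chlorophenyl on an amine nitrogen in a ring. The most relevant comparison is a 1.1-fold lower number from compound 1 to compound 3 (0.05 log units; within the scatter), which also moves the chloro from one position of the phenyl to another and stays within the scatter. On that basis the step of no change at the digits printed from compound 3 to compound 4 (within the scatter) is expected to be small, with no direction beyond the scatter. Compound 4 is therefore estimated at 15 nM, with a range from 6 nM to 40 nM.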

Compound 4, inhibition constant: 8.4 nM
Beside the measured number, compound 4's estimate is 1.8-fold (0.25 log units) above it, within the range that was stated.
By their numbers in this assay, from the lowest: compounds 4, 2, 3 and 1 (each within the scatter of the next, the first and the last beyond it).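

In this assay, within the data shown here, the chloro position on the phenyl now gives the first step beyond the scatter: a 2.0-fold lower number from compound 1 to compound 4 (0.31 log units; beyond the scatter), a modest step for 3-chlorophenyl in place of 4-chlorophenyl. The other two new steps stay within the scatter, a 1.8-fold lower number from compound 3 to compound 4 (0.25 log units; within the scatter) and a 1.0-fold lower number from compound 2 to compound 4 (0.02 log units; within the scatter), so 3-chlorophenyl cannot be told apart from 2-chlorophenyl or 2-ethoxyphenyl at this amine nitrogen, and the 4-chlorophenyl to 3-chlorophenyl pair is the only one here that separates. Nothing available bears on why this one change reaches past the scatter.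

From the compounds shown here alone, whether the chloro itself matters at this position stays open, since an unsubstituted phenyl, a 3-bromophenyl, a 3-ethoxyphenyl or a pyridine ring on the same nitrogen would each test a different part of the result. Also open, going by these compounds, is whether the small gap between 4-chlorophenyl and 3-chlorophenyl holds when the difluorophenyl on the shared core is replaced by another aryl group, or whether it stays this modest with repeated measurement.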